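A few compounds are considered here, and "the series" means these few. Any claim that something is new, unique, unknown or untested is made for them only; others in the source may bear on it.

Compound 1 `N=C(Nc1ccccc1)c1cc2c(-c3ccccc3)n[nH]c2c(NC2CCCCC2)n1` and compound 2 `CN1CCN(c2ccc(NC(=N)c3cc4c(-c5ccccc5)n[nH]c4c(NC4CCCCC4)n3)cc2)CC1` share one core, while compound 3 `N=C(Nc1ccccc1)c1cc2c(-c3ccccc3)n[nH]c2cn1` and compound 4 `CN1CCN(c2ccc(NC(=N)c3cc4c(-c5ccccc5)n[nH]c4cn3)cc2)CC1` share another. In a functional assay on HT-1080 cells (Homo sapiens) for cytotoxicity, read by MTT assay, with a stated time of 72 h (a higher number here means a weaker inhibitor, a lower number a stronger inhibitor), compound 1 gives 850 nM, compound 2 gives 650 nM and compound 3 gives 22000 nM. Within the data shown here, the two cores differ by hydrogen in place of cyclohexylamino on an aromatic carbon, and that difference carries the only large step seen here, a 26-fold higher number from compound 1 to compound 3 (1.41 log units; beyond the scatter). On the first core the change 4-methylpiperazin-1-yl in place of hydrogen on an aromatic carbon produced a 1.3-fold lower number from compound 1 to compound 2 (0.12 log units; within the scatter), a step that does not rise above the usual noise of this assay. Compound 4 arises from compound 3 by 4-methylpiperazin-1-yl in place of hydrogen on an aromatic carbon; the group that leaves, the group that enters and the place are described in the same words, so this is the same change seen a second time, now on the weaker core. Compound 4 has not yet been measured in this assay. Among the measured compounds shown here, the expectation for it rests on the single precedent a 1.3-fold lower number from compound 1 to compound 2 (0.12 log units; within the scatter), which is small. Compound 4 is therefore expected to give about 17000 nM in this assay, with a plausible range of 7000 nM to 45000 nM. The estimated step of a 1.3-fold lower number from compound 3 to compound 4 (0.11 log units; within the scatter) is expected to stay within the scatter, like the earlier one.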

Compound 4, half-maximal inhibitory concentration: 11400 nM
Compound 4: the middle estimate sits 1.5-fold (0.17 log units) above what was measured; measured number inside the range.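

In this assay, 4-methylpiperazin-1-yl in place of hydrogen gives a 1.9-fold lower number from compound 3 to compound 4 (0.29 log units; within the scatter), and this step does not differ from the earlier one on the other core: the same change on two cores in this assay, a 1.3-fold lower number (0.12 log units; within the scatter) from compound 1 to compound 2 and a 1.9-fold lower number (0.29 log units; within the scatter) from compound 3 to compound 4, 1.5-fold (0.17 log units) apart, within the scatter of two such steps. Hydrogen in place of cyclohexylamino gives an 18-fold higher number from compound 2 to compound 4 (1.24 log units; beyond the scatter), so this large step also carries over, with or without the 4-methylpiperazin-1-yl group: the same change on two cores in this assay, a 26-fold higher number (1.41 log units; beyond the scatter) from compound 1 to compound 3 and an 18-fold higher number (1.24 log units; beyond the scatter) from compound 2 to compound 4, 1.5-fold (0.17 log units) apart, within the scatter of two such steps. Both changes therefore read consistently across the compounds shown, but the 4-methylpiperazin-1-yl steps stay within the scatter on both cores, so no effect of that group is shown on either, and two pairs in one assay say nothing about other cores or other cells.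

Still open, as far as these compounds go, is how a smaller amine, such as cyclopropylamino, or an open-chain alkylamine would compare with cyclohexylamino in the same place. Also open, from the compounds shown here alone, is whether morpholine or a carboxylic acid in place of 4-methylpiperazin-1-yl would give a step beyond the scatter on either core.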